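This account rests on a few compounds, and the source may have more. Where it says the series, first, only, none or still open, it means among the compounds named here.

Working notes on the series. The shared core carries a sulfonyl-linked aryl group and an amide at the saturated ring. Compound 1 `O=C([C@@H]1CCCN(S(=O)(=O)c2ccc(S(=O)(=O)C3CCC3)cc2)C1)N1CCC(F)(F)CC1` gives 78 nM in a functional assay on BXPC-3 cells (Homo sapiens) for inhibition, read by MTT assay, with a stated time of 7 days; a higher number here means a weaker inhibitor, a lower number a stronger inhibitor. Within the data shown here, compound 3 `CCN(CC)C(=O)c1ccc(S(=O)(=O)N2CCC[C@@H](C(=O)N3CCC(F)(F)CC3)C2)cc1` gives 240 nM; the step of a 3.1-fold higher number from compound 1 to compound 3 (0.49 log units; beyond the scatter) is the only single-point step measured so far, and it concerns the aryl substituent, not the amide. Compound 2 `CCN(CC)S(=O)(=O)c1ccc(S(=O)(=O)N2CCC[C@@H](C(=O)N3CCS(=O)(=O)CC3)C2)cc1` gives 4430 nM, the highest of the three numbers, beyond the scatter from both compound 3 and compound 1; compound 2 and compound 1 differ in two places, so their values are only compared, not read as a step.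

Compound 4 `CCN(CC)S(=O)(=O)c1ccc(S(=O)(=O)N2CCC[C@@H](C(=O)NC3COC3)C2)cc1` differs from compound 2 by (oxetan-3-yl)amino in place of 1,1-dioxothiomorpholin-4-yl on a carbonyl carbon. Among the measured compounds shown here, no measured step bears on this change: the one step recorded sits on the aromatic carbon and says nothing about the amide. The expectation is therefore anchored on compound 2 alone, with a step of a 1.3-fold lower number from compound 2 to compound 4 (0.10 log units; within the scatter) expected to stay within the scatter, in no firm direction. Compound 4 is thus estimated at 3500 nM, with a range from 800 nM to 15000 nM.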

Compound 4, half-maximal inhibitory concentration: 13800 nM
Beside the measured number, compound 4's estimate is 3.9-fold (0.60 log units) below it; low and high end bracket the measured number.
By their numbers in this assay, from the lowest: compound 1; then compound 3; then compound 2; then compound 4.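

In this assay, among these compounds, the carbonyl carbon responds to substitution: a 3.1-fold higher number from compound 2 to compound 4 (0.49 log units; beyond the scatter), a change beyond the scatter and the first measured step at this position, as the earlier step concerned only the aromatic carbon. The change from 1,1-dioxothiomorpholin-4-yl to (oxetan-3-yl)amino replaces a six-membered ring with a four-membered one and adds the amide hydrogen, and this combined change goes with a weaker inhibitor in this series. No measured property accounts for this step.

Among the compounds shown here, the single step does not separate ring size from the amide hydrogen. An azetidin-1-yl group on the same carbonyl carbon, which carries no amide hydrogen, and a (tetrahydropyran-4-yl)amino group, which keeps the amide hydrogen on a larger ring, would leave these two changes apart.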